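The source may report more compounds than this note shows. Statements on the series, on what has been measured and on what is new or still open speak of the compounds shown alone.

Measured so far in a functional assay on LOX IMVI cells (Homo sapiens) for inhibition, read by sulforhodamine B assay, with a stated time of 48 h; a higher number here means a weaker inhibitor of growth, a lower number a stronger inhibitor of growth:

compound 1 `COc1ccc(CNc2nc3cc(N)cc(N)c3nc2-c2ccccc2)cc1OC`: 3090 nM
compound 2 `COc1cc(CNc2nc3cc(N)cc(N)c3nc2-c2ccccc2)cc(OC)c1OC`: 3160 nM

Compound 1 holds the lower of the two numbers, but compound 2 lies within the scatter of it, so no order between them can be read from this assay. For the measured compounds named here, the single comparison available, a 1.0-fold higher number from compound 1 to compound 2 (0.01 log units; within the scatter), shows that adding a methoxy to the benzyl ring of compound 1 leaves the read-out where it was.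

Compound 3 `COc1ccc(CNc2nc3cc(N)cc(N)c3nc2-c2ccccc2)cc1` is the next member of the series to be considered. Its difference from compound 1 is hydrogen in place of methoxy on an aromatic carbon. Going by the values given here, the only measured step that bears on this change is a 1.0-fold higher number from compound 1 to compound 2 (0.01 log units; within the scatter): one methoxy more on the same benzyl ring gave no shift beyond the scatter. Among the compounds with values here, compound 3 goes the other way, one methoxy fewer, and nothing among the measured compounds suggests that the count of methoxy groups on this ring moves the number in this assay. The expectation for compound 3 is therefore a step of a 1.0-fold higher number from compound 1 to compound 3 (0.00 log units; within the scatter), that is, nothing beyond the scatter. Compound 3 is estimated at 3100 nM, with a range of 1400 nM to 7000 nM.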

Compound 3, concentration for 50% growth inhibition: 13500 nM
Estimate against measurement, compound 3: 4.4-fold (0.64 log units) below; measured number outside the range, above it.
By their numbers in this assay, from the lowest: compounds 1 and 2 (each within the scatter of the next); then compound 3.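

In this assay, the methoxy on an aromatic carbon ortho to a methoxy group and meta to a large group turns out to matter: the change from 3,4-dimethoxyphenyl to 4-methoxyphenyl gives a modest step toward a weaker inhibitor of growth (a 4.4-fold higher number from compound 1 to compound 3 (0.64 log units; beyond the scatter)). Set against the step on adding a further methoxy to the same ring (a 1.0-fold higher number from compound 1 to compound 2 (0.01 log units; within the scatter)), this shows that the number does not simply follow the count of methoxy groups: one addition leaves it within the scatter, while this one removal moves it beyond the scatter. No measurement at hand gives a reason for the step.

Still open, going by these compounds, is whether the methoxy itself is needed at this carbon or whether another group, such as hydroxy, ethoxy or chlorine, would hold the number of compound 1 (3090 nM). Also open, on these data alone, is what the remaining methoxy of the 4-methoxyphenyl group contributes, which a plain phenyl in its place would show.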